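This account rests on a few compounds, and the source may have more. Where it says the series, first, only, none or still open, it means among the compounds named here.

This account concerns two measured compounds and a third still to be measured, all read in an ADME assay on MT4 cells (Homo sapiens) for cytotoxicity, read by MTT assay, with a stated time of 5 days; on this read-out higher numbers stand for lower toxicity in this test and lower numbers for higher toxicity in this test. For the measured compounds named here, compound 1 `Cc1cc(/C=C/C#N)cc(C)c1Oc1nc(Nc2ccc(CN3CCN(S(C)(=O)=O)CC3)cc2)nc2sccc12` carries a (4-(methylsulfonyl)piperazin-1-yl)methyl group on an aromatic carbon; in this assay compound 1 gives 131000 nM, the only definite number available here. Compound 2 `Cc1cc(/C=C/C#N)cc(C)c1Oc1nc(Nc2ccc(N3CCN(S(N)(=O)=O)CC3)cc2)nc2ccsc12` is a related structure. In this assay compound 2 gives > 222000 nM, which is a limit of the assay rather than a number, so that the limit of > 222000 nM in this assay, at which 1 of the 2 values shown sits, is all that is known of it. Compound 3 `Cc1cc(/C=C/C#N)cc(C)c1Oc1nc(Nc2ccc(N3CCN(S(C)(=O)=O)CC3)cc2)nc2sccc12` differs from compound 1 in one place: 4-(methylsulfonyl)piperazin-1-yl in place of (4-(methylsulfonyl)piperazin-1-yl)methyl on an aromatic carbon. Going by the values given here, no step between two measured compounds is available, so the size of this change in this assay remains open. Given that compound 1 sits at 131000 nM, compound 3 is expected to stay close, with a step of a 1.1-fold higher number from compound 1 to compound 3 (0.06 log units; within the scatter) expected to be no larger than the scatter in either direction. Compound 3 is therefore estimated at 150000 nM, with a range from 70000 nM to 320000 nM, and a fair chance that only a limit is reported.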

Compound 3, half-maximal cytotoxic concentration: > 222000 nM
Compound 3 gave a limit, no number; the forecaster's own chance of this, stated with the estimate: 40%; at least 1.4-fold (0.17 log units) between middle value and limit.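

Where the earlier compounds offered no step at this position, placing 4-(methylsulfonyl)piperazin-1-yl in place of (4-(methylsulfonyl)piperazin-1-yl)methyl on the aromatic carbon now gives, in this assay, an at least 1.6-fold higher number from compound 1 to compound 3 (0.22 log units; that floor lies within the scatter). The figure is only a floor, since the reading for compound 3 is a limit of the assay and not a number, so the change cannot be called a real difference, yet the result leaves no room for a number lower than that of compound 1. The result is again a limit of the assay: the limit of > 222000 nM in this assay, at which 2 of the 3 values shown sit.

Going by these compounds, the true distance between compound 1 and compound 3 stays open, as does whether the same change would read alike on a different core. Also open, on these data alone, is whether an amine, a carboxylic acid or a longer chain at this position on the aromatic ring would give a definite number in this assay.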